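The source may hold more compounds than are shown below. What is called first, only, known or untested is meant among the compounds shown, and "the series" means these compounds.

Compound 1 `COc1ccccc1C(=O)Nc1nnc(-c2ccc(Cl)cc2)s1` gives 53.7 nM in a functional assay on the whole organism (integument) for inhibition, with Chilo suppressalis as the target, read by scintillation counting, with a stated time of 72 h; a lower number here means a stronger inhibitor, a higher number a weaker inhibitor. For compound 2 `CCOc1ccccc1C(=O)Nc1nnc(-c2ccc(Cl)cc2)s1` this assay reports only a limit, > 5010 nM. The step of an at least 93-fold higher number from compound 1 to compound 2 (1.96 log units; beyond the scatter) goes with the change (methyl in place of hydrogen on a saturated chain carbon bound to an oxygen on an aromatic ring). Compound 3 `COc1cccc(OC)c1C(=O)Nc1nnc(-c2ccc(C(C)C)cc2)s1` gives 398 nM in this assay; how its core differs from the core of compound 1 is not broken down here. Compound 4 `COc1cccc(OC)c1C(=O)Nc1nnc(-c2ccc(C(C)(C)C)cc2)s1` has not yet been measured; it differs from compound 3 by methyl in place of hydrogen on a saturated chain carbon bound to an aromatic carbon and two saturated chain carbons. This is the same kind of change as that from compound 1 to compound 2, but not the same: there the carbon is bound to an oxygen on an aromatic ring, here to an aromatic carbon and two saturated chain carbons. A smaller step is expected here, a 1.6-fold higher number from compound 3 to compound 4 (0.20 log units; within the scatter). For the measured compounds named here, that expectation rests on the earlier step of an at least 93-fold higher number from compound 1 to compound 2 (1.96 log units; beyond the scatter) sitting at a different place, with no matching step measured at this one. For compound 4 the estimate is 630 nM, between 150 nM and 3000 nM.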

Compound 4, half-maximal inhibitory concentration: 912 nM
Compound 4: middle estimate off by 1.4-fold (0.16 log units), on the low side; the range from low to high includes it.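

In this assay, methyl in place of hydrogen gives a 2.3-fold higher number from compound 3 to compound 4 (0.36 log units; beyond the scatter), and the size of the step does not carry from one core to the other: the same change on two cores in this assay, an at least 93-fold higher number (1.96 log units; beyond the scatter) from compound 1 to compound 2 and a 2.3-fold higher number (0.36 log units; beyond the scatter) from compound 3 to compound 4, at least 40-fold (1.60 log units) apart, beyond the scatter of two such steps

Core and place change together across these two steps, and the pair does not show which of the two sets the size. For compound 2 the reading of > 5010 nM is a limit of the assay and not a number.

From the compounds shown here alone, a longer chain or an amine in place of the tert-butyl remains open. Also open, going by these compounds, is whether the same change at one place gives a matching step on the other core.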